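The source may report more compounds than this note shows. Statements on the series, on what has been measured and on what is new or still open speak of the compounds shown alone.

Measured in an ADME assay on microsomes from liver (Rattus norvegicus) for metabolic stability, read by LC-MS, using NADPH, at 37 degrees C; on this read-out lower numbers stand for a shorter-lived compound and higher numbers for a longer-lived compound:
- Compound 1 `Cc1ccc(-c2nc(CN3CCC(C(=O)NCCCN4C[C@H](C)C[C@H](C)C4)CC3)c(C)o2)cc1`: > 0.5 h, a limit of the assay
- Compound 2 `COc1cccc(Cl)c1-c1nc(CN2CCC(C(=O)NCCCN3C[C@H](C)C[C@H](C)C3)CC2)c(C)o1`: 0.055 h
- Compound 3 `COc1cccc(F)c1-c1nc(CN2CCC(C(=O)NCCCN3C[C@H](C)C[C@H](C)C3)CC2)c(C)o1`: 0.143 h

Of the two values that are true numbers, the higher belongs to compound 3, and a 2.6-fold higher number from compound 2 to compound 3 (0.41 log units; beyond the scatter) separates it from its nearest neighbour. Compound 4 `Cc1cccc(C)c1-c1nc(CN2CCC(C(=O)NCCCN3C[C@H](C)C[C@H](C)C3)CC2)c(C)o1` carries 2,6-dimethylphenyl in place of 2-fluoro-6-methoxyphenyl on an aromatic carbon. Going by the values given here, no measured step makes this exact exchange. The closest guide is an at least 3.4-fold lower number from compound 1 to compound 3 (0.54 log units; beyond the scatter), which links compound 3 to a compound that, like compound 4, has a methyl-bearing phenyl and no methoxy. Against that, compound 4 keeps two groups on the phenyl, as compound 2 and compound 3 do, and a 2.6-fold higher number from compound 2 to compound 3 (0.41 log units; beyond the scatter) shows that swapping one of them alone can move the number. A small rise, staying within the scatter, is therefore expected in this assay. The expected change is a 1.3-fold higher number from compound 3 to compound 4 (0.10 log units; within the scatter). For compound 4 the estimated half-life is 0.18 h, with an expected range of 0.06 h to 0.5 h.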

Compound 4, half-life: 0.0517 h
For compound 4 the middle estimate is 3.5-fold (0.54 log units) above the measured one, outside the stated range (below it).
By their numbers in this assay, from the lowest: compounds 4 and 2 (each within the scatter of the next); then compound 3. At a limit, above all of these: compound 1.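

In this assay, 2,6-dimethylphenyl in place of 2-fluoro-6-methoxyphenyl gives a 2.8-fold lower number from compound 3 to compound 4 (0.44 log units; beyond the scatter), so a short half-life at this position does not depend on a methoxy group. The change from the chloro-bearing compound gives a 1.1-fold lower number from compound 2 to compound 4 (0.03 log units; within the scatter), placing two differently substituted phenyl groups within the scatter of each other, while compound 3 stays apart from both. All three compounds with two groups on the phenyl lie under the 4-methylphenyl compound, and an at least 9.6-fold lower number from compound 1 to compound 4 (0.98 log units; beyond the scatter) rests on a limit of the assay, not a number: the limit of > 0.5 h in this assay, at which 1 of the 4 values shown sits.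

The compounds shown leave open how an unsubstituted phenyl, or a phenyl bearing a single methyl or only fluoro groups, would behave at this position. From the compounds shown here alone, whether a nitrile or a carboxylic acid on the phenyl would shift the half-life also remains open.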